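Series notes: amine substituent on the shared core

The compounds below may be only part of what the source reports. "The series", "measured", "known", "first", "only" and "open" are said of these compounds alone.

Measured so far:
compound 1, `CC(C)NCc1nnc(-c2ccccc2-c2ccccc2)s1`: 23 mg/kg
compound 2, `NCc1nnc(Cc2ccccc2)s1`: 110 mg/kg

In a functional assay on the whole organism with Mus musculus as the target (on this read-out lower numbers stand for an effect already at smaller amounts and higher numbers for an effect only at larger amounts of compound), compound 1 gives 23 mg/kg, the lower of the two numbers at hand. Within the data shown here, compound 2 gives 110 mg/kg in this assay, and the gap between these two values lies beyond the usual scatter, so compound 1 is the more potent of the measured pair; compound 2 differs from it in more than one place, and no single step between the two is counted.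

Compound 3, `c1ccc(CNCc2nnc(-c3ccccc3-c3ccccc3)s2)cc1`, is not yet measured in this assay. It differs from compound 1 by benzyl in place of isopropyl on an amine nitrogen. Among the measured compounds shown here, no measured step covers this change, so the size of the step from compound 1 to compound 3 is open; an estimate of about no change beyond the scatter, with a slight lean toward a higher dose, seems the fair reading, since the core and the amine are kept. The estimated step is a 1.3-fold higher number from compound 1 to compound 3 (0.12 log units; within the scatter). For compound 3 the expected value in this assay is 30 mg/kg, in a range from 10 mg/kg to 90 mg/kg.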

Compound 3, dose for half-maximal effect: 37 mg/kg
Compound 3: the middle estimate sits 1.2-fold (0.09 log units) below what was measured, and the stated range covers the measured number.
By their numbers in this assay, from the lowest: compounds 1 and 3 (each within the scatter of the next); then compound 2.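

On the amine nitrogen of the shared core, benzyl in place of isopropyl gives a 1.6-fold higher number from compound 1 to compound 3 (0.21 log units; within the scatter) in this assay, so at this place a group of 7 heavy atoms with a six-membered aromatic ring reads the same as one of 3 heavy atoms with no ring. Among these compounds, this is the first single-place step at this nitrogen, as compound 1 and compound 2 differ in more than one place and gave no such reading. Nothing at hand speaks to a cause for this result.

Open, as far as these compounds go, is whether a longer chain ending in a carboxylic acid or a hydroxyl on this nitrogen would also read the same. Also open, from the compounds shown here alone, is how the bare amine reads on the core of compound 1, a question compound 2 does not settle.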